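Para-fluoro on the benzamide: compound 3 to compound 4

The source may hold more compounds than are shown below. What is called first, only, known or untested is meant among the compounds shown, and "the series" means these compounds.

Measured compounds:
compound 1, `COc1cccc(-c2nn(-c3ccccc3)cc2-c2ccnc(NCCNC(=O)Nc3cccc(C(F)(F)F)c3)c2)c1`, 1980 nM
compound 2, `COc1cccc(-c2nn(-c3ccccc3)cc2-c2ccnc(NCCCNC(=O)Nc3ccc(Cl)c(Cl)c3)c2)c1`, 2440 nM
compound 3, `O=C(NCCCNc1cc(-c2cn(-c3ccccc3)nc2-c2cccc(O)c2)ccn1)c1ccccc1`, 2300 nM

All three numbers come from a functional assay on cells (Panel colon (Carcinoma cell lines), Homo sapiens) for antiproliferative activity; a higher number here means a weaker inhibitor of growth, a lower number a stronger inhibitor of growth. Compound 3 stands second highest of the three; its nearest neighbour is compound 2, whose number is higher by an amount within the scatter, and the furthest is compound 1, whose number is lower by an amount that is also within the scatter. The three compounds therefore cannot be ordered against one another on these data.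

Compound 4, `O=C(NCCCNc1cc(-c2cn(-c3ccccc3)nc2-c2cccc(O)c2)ccn1)c1ccc(F)cc1`, differs from compound 3 by fluoro in place of hydrogen on an aromatic carbon of the benzoyl ring, para to a large group. Among the measured compounds shown here, no pair of measured compounds shows this change, so there is no step to lean on. The expectation is that the step of a 1.2-fold lower number from compound 3 to compound 4 (0.06 log units; within the scatter) stays within the scatter, with no clear direction. Compound 4 is thus estimated at 2000 nM in this assay, with a range from 900 nM to 4500 nM.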

Compound 4, concentration for 50% growth inhibition: 2160 nM
Estimate against measurement, compound 4: 1.1-fold (0.03 log units) below, within the range that was stated.
By their numbers in this assay, from the lowest: compounds 1, 4, 3 and 2 (each within the scatter of the next).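

In this assay, among the compounds shown here, fluoro in place of hydrogen on an aromatic carbon of the benzoyl ring, para to a large group, gives a 1.1-fold lower number from compound 3 to compound 4 (0.03 log units; within the scatter) and is the first single-place step available. Phenyl to 4-fluorophenyl therefore leaves the reading at this position indistinguishable from that of the parent benzamide, which the earlier compounds, differing in several places at once, could not show. No measurement on hand accounts for the size of this step.

Still open, going by these compounds, is whether an amine or a carboxylic acid at the same place on the benzoyl ring would give a step beyond the scatter. Also open, on these data alone, is whether a longer chain carrying the benzamide would leave the number as unchanged as fluoro does.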